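Replacing Methoxy with Methylcarbamoyl on the Shared Core

The source may hold more compounds than are shown below. What is called first, only, known or untested is meant among the compounds shown, and "the series" means these compounds.

Compound 1 `CN(C)C(=O)c1coc(C(=O)CCCCCCc2ccccc2)n1` carries a dimethylcarbamoyl group, and in an assay on HEK-293T cells for inhibition of diacylglycerol lipase-alpha (Homo sapiens), read by colorimetric assay (a lower number here means a stronger inhibitor, a higher number a weaker inhibitor), compound 1 gives 3390 nM. Compound 2 `COc1coc(C(=O)CCCCCCc2ccccc2)n1` carries methoxy instead, and in this assay compound 2 reaches only > 10000 nM, a limit rather than a number. That single measured step, an at least 2.9-fold higher number from compound 1 to compound 2 (0.46 log units; beyond the scatter), is the one that bears on the new change, and it rests on (the limit of > 10000 nM in this assay, at which 1 of the 2 values shown sits). Compound 3 `CNC(=O)c1coc(C(=O)CCCCCCc2ccccc2)n1` differs from compound 2 by methylcarbamoyl in place of methoxy on an aromatic carbon, bringing back an amide. The step is expected to be an at least 2.5-fold lower number from compound 2 to compound 3 (0.39 log units; beyond the scatter), roughly undoing the measured loss. Compound 3 is therefore estimated at 4000 nM, within 1500 nM to 12000 nM.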

Compound 3, half-maximal inhibitory concentration: > 10000 nM
Compound 3 was reported as a limit; the forecaster's own chance of this, stated with the estimate: 25%; at least 2.5-fold (0.39 log units) between middle value and limit.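

Bringing back an amide at this position does not by itself bring back a readable value: compound 3, with its methylcarbamoyl group, is reported only as a limit, > 10000 nM. Hydrogen in place of methyl on the amide-type nitrogen gives an at least 2.9-fold higher number from compound 1 to compound 3 (0.46 log units; beyond the scatter), so of these three compounds only compound 1, with dimethylcarbamoyl, has a measured number. The step between compound 2 and compound 3 cannot be read, since both values are limits: the limit of > 10000 nM in this assay, at which 2 of the 3 values shown sit.

Methoxy and methylcarbamoyl therefore cannot be ranked against each other. Going by these compounds, whether a carboxylic acid or a diethylcarbamoyl group at this position would give a lower number than compound 1 stays open.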